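Sulfonamide aryl change: compound 3 to compound 4

This account rests on a few compounds, and the source may have more. Where it says the series, first, only, none or still open, it means among the compounds named here.

Values in a functional assay on HT-29 cells (Homo sapiens) for antiproliferative activity, read by sulforhodamine B assay, with a stated time of 48 h; a lower number here means a stronger inhibitor, a higher number a weaker inhibitor:
compound 1 `Cc1cccc(NS(=O)(=O)c2ccc(N3CCNC3=O)cc2)c1`: 110 nM
compound 2 `Cc1cc(C)cc(NS(=O)(=O)c2ccc(N3CCNC3=O)cc2)c1`: 82 nM
compound 3 `O=C1NCCN1c1ccc(S(=O)(=O)Nc2ccc(Br)cc2)cc1`: 300 nM

Compound 3 has the highest number of the three. Compound 4 `Cc1ccc(C)c(NS(=O)(=O)c2ccc(N3CCNC3=O)cc2)c1` carries 2,5-dimethylphenyl in place of 4-bromophenyl on a sulfonamide nitrogen. For the measured compounds named here, two measured steps bear on this change, both modest, and both end at the 4-bromophenyl group: a 2.7-fold higher number from compound 1 to compound 3 (0.44 log units; beyond the scatter) and a 3.7-fold higher number from compound 2 to compound 3 (0.56 log units; beyond the scatter). The step of a 1.3-fold lower number from compound 1 to compound 2 (0.13 log units; within the scatter) compares the two methyl-bearing compounds. Going by the values given here, the 2,5-dimethylphenyl group itself has no measured precedent, so the comparison is indirect. A reversal of similar size, towards a lower number in this assay, is expected, with an estimated change of a 3.0-fold lower number from compound 3 to compound 4 (0.48 log units; beyond the scatter). For compound 4 the estimate is 100 nM, with an expected range of 45 nM to 220 nM.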

Compound 4, half-maximal inhibitory concentration: 46 nM
For compound 4 the middle estimate is 2.2-fold (0.34 log units) above the measured one, and the stated range covers the measured number.
By their numbers in this assay, from the lowest: compounds 4, 2 and 1 (each within the scatter of the next, the first and the last beyond it); then compound 3.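

Against 4-bromophenyl, 2,5-dimethylphenyl on a sulfonamide nitrogen gives a 6.5-fold lower number from compound 3 to compound 4 (0.81 log units; beyond the scatter) in this assay, and this is the widest step in the series so far. The two dimethylphenyl patterns are not separated: a 1.8-fold lower number from compound 2 to compound 4 (0.25 log units; within the scatter) lies within the scatter. A second methyl now matters in one case, with a 2.4-fold lower number from compound 1 to compound 4 (0.38 log units; beyond the scatter) beyond the scatter, whereas a 1.3-fold lower number from compound 1 to compound 2 (0.13 log units; within the scatter) stays within it.

No measurement here explains these steps. On these data alone, whether an aryl group carrying an amine or a carboxylic acid on the sulfonamide nitrogen keeps this level remains open.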